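A few compounds are considered here, and "the series" means these few. Any claim that something is new, unique, unknown or untested is made for them only; others in the source may bear on it.

Compound 1 `Fc1cccc(-c2nc(Nc3ccccc3)c3cc(F)ccc3n2)c1` gives 47800 nM in a functional assay on MDA-MB-231 cells (Homo sapiens) for cytotoxicity, read by MTT assay, with a stated time of 48 h; on this read-out lower numbers stand for stronger inhibition and higher numbers for weaker inhibition. Compound 2 `COc1ccccc1Nc1nc(-c2cccc(F)c2)nc2ccc(F)cc12` gives only a limit, > 50000 nM. Compound 3 `Fc1cccc(-c2nc(Nc3ccccc3F)c3cc(F)ccc3n2)c1` likewise gives only a limit, > 50000 nM.

For the measured compounds named here, compound 2 therefore stands at a limit and not at a number; it sits at the limit of > 50000 nM in this assay, at which 2 of the 3 values shown sit, together with compound 3, while compound 1 is the only compound with a read value. Compound 4 `Fc1cccc(-c2nc(Nc3ccccc3Br)c3cc(F)ccc3n2)c1` differs from compound 2 by bromo in place of methoxy on an aromatic carbon. The measured steps at this position are an at least 1.0-fold higher number from compound 1 to compound 2 (0.01 log units; that floor lies within the scatter) and an at least 1.0-fold higher number from compound 1 to compound 3 (0.01 log units; that floor lies within the scatter), both floors, and a step that the two limits leave unreadable from compound 2 to compound 3. Going by the values given here, no step involves bromo, so no direction beyond the scatter can be expected in this assay. Compound 4 is estimated at 60000 nM (range 20000 nM to 200000 nM), a step that the limit leaves unreadable from compound 2 to compound 4 that is expected to remain near the limit.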

Compound 4, half-maximal inhibitory concentration: > 50000 nM
Compound 4: a limit, no number; the forecaster's own chance of this, stated with the estimate: 70%; the middle value lies beyond the limit too.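

Bromo in place of hydrogen on this aromatic carbon gives an at least 1.0-fold higher number from compound 1 to compound 4 (0.01 log units; that floor lies within the scatter). The steps from compound 2 and from compound 3 to compound 4 cannot be read, as each joins two limits. Methoxy, fluoro and bromo on this carbon thus all leave their compounds at one shared limit in this assay: the limit of > 50000 nM in this assay, at which 3 of the 4 values shown sit.

Going by these compounds, whether an amine or a carboxylic acid on this carbon would move the number away from that of compound 1, 47800 nM, stays open. On these data alone, how far compound 2, compound 3 and compound 4 lie beyond their limit also stays open.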